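This account rests on a few compounds, and the source may have more. Where it says the series, first, only, none or still open, it means among the compounds named here.

Measured compounds:
Compound 1, `[N-]=[N+]=NCC(O)Cn1c(=O)n(C2OC(CO)[C@@H](O)[C@H]2O)c2nc(N)nc(O)c21`: in a functional assay on the whole organism (B cells) with Mus musculus as the target (on this read-out higher numbers stand for larger maximal responses and lower numbers for smaller maximal responses), compound 1 gives 91%.
Compound 2, `CC1(C)O[C@@H]2[C@H](O1)[C@@H](CO)O[C@H]2n1c(=O)n(C/C=C/c2ccccc2)c2c(O)nc(N)nc21`: in this assay compound 2 gives 16%.

Of these two numbers, compound 2 stands lowest; its nearest neighbour is compound 1, whose maximal response lies far above it, well beyond the scatter of the method. Compound 1 and compound 2 differ in more than one place, so their gap cannot be tied to a single change.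

Compound 3, `Cn1c(=O)n([C@@H]2O[C@H](CO)[C@H]3OC(C)(C)O[C@H]32)c2nc(N)nc(O)c21`, has not yet been measured in this assay. It differs from compound 2 in one place only: hydrogen in place of 2-phenylethenyl on a saturated chain carbon bound to an aromatic nitrogen. The group that leaves is 2-phenylethenyl, and a hydrogen takes its place on a saturated chain carbon bound to an aromatic nitrogen.

Within the data shown here, with no single-change step available for guidance, the expected step of a number 24 percentage points higher from compound 2 to compound 3 (beyond the scatter) is an upward one of modest size, given that compound 2 sits so low at 16%. The estimated maximal response for compound 3 is 40%, with a range from 10% to 80%.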

Compound 3, largest response reached (reported as maximal response), in percent of the reference or control that the assay uses: 193%
Compound 3: middle estimate off by 153 percentage points, on the low side; the measured number lies above the stated range.
By their numbers in this assay, from the lowest: compound 2; then compound 1; then compound 3.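

In this assay, this place on the molecule carries great weight: putting hydrogen in place of 2-phenylethenyl on a saturated chain carbon bound to an aromatic nitrogen gives a large rise, a number 177 percentage points higher from compound 2 to compound 3 (beyond the scatter). Among these compounds, this is the first single-change comparison, so a gap can now be tied to one place, with methyl going with the higher response and 3-phenylprop-2-en-1-yl with the lower one. Nothing measured here explains why the response moves this way.

With only these two groups compared at this place, a single step cannot separate the part played by the aromatic ring, the double bond or the length of the chain. An ethyl group or a saturated 3-phenylpropyl chain at the same place would help to tell these apart.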